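Para substituent on the benzyl arm of the shared core

This account rests on a few compounds, and the source may have more. Where it says the series, first, only, none or still open, it means among the compounds named here.

Compound 1 (`CN1CCC[C@@H]1Cn1nc(Cc2ccc(C(C)(C)C)cc2)c2ccccc2c1=O`) carries a tert-butyl group on its benzyl ring. In an assay for binding affinity to Alpha-1A adrenergic receptor (Homo sapiens) (on this read-out lower numbers stand for stronger inhibition and higher numbers for weaker inhibition), compound 1 gives only a limit, > 1990 nM, and no number. This sits at the limit of > 1990 nM in this assay, at which 1 of the 3 values shown sits, so where compound 1 stands within the series cannot be told beyond that it does not bind within the measured window. Compound 3 (`CN1CCC(Cn2nc(Cc3ccc(Cl)cc3)c3ccccc3c2=O)C1`), which bears a chlorine on the benzyl ring and a differently attached pyrrolidine, gives 100 nM in this assay. Compound 2 (`O=c1c2ccccc2c(Cc2ccc(Cl)cc2)nn1C[C@H]1CCCN1CCCCCc1ccc(OCCCN2CCCCCC2)cc1`), with the same chlorine and a long chain on the pyrrolidine nitrogen, gives 25.1 nM in this assay.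

Compound 4 (`COc1ccc(Cc2nn(C[C@H]3CCCN3C)c(=O)c3ccccc23)cc1`) differs from compound 1 by methoxy in place of tert-butyl on an aromatic carbon. Among the compounds with values here, no measured pair shows this exchange. The expected step from compound 1 to compound 4 is an at least 2.4-fold lower number from compound 1 to compound 4 (0.39 log units; beyond the scatter), toward stronger binding, but modest and uncertain given that compound 1 stands only at a limit. Compound 4 is estimated at 800 nM in this assay, within a range of 150 nM to 5000 nM.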

Compound 4, inhibition constant: 126 nM
The estimate for compound 4 lay 6.3-fold (0.80 log units) above the measured number, and the stated range ends above it.
By their numbers in this assay, from the lowest: compound 2; then compounds 3 and 4 (each within the scatter of the next). At a limit, above all of these: compound 1.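

With the rest of the molecule unchanged, methoxy in place of tert-butyl on an aromatic carbon gives an at least 15-fold lower number from compound 1 to compound 4 (1.19 log units; beyond the scatter) in this assay. Within the data shown here, this is the first one-place comparison, and it shows that the group at this position of the benzyl ring has a large bearing on the read-out. The size of the step is only a bound, since compound 1 stands at a limit and not at a number: the limit of > 1990 nM in this assay, at which 1 of the 4 values shown sits.

The exchange changes the heavy-atom count and adds a hydrogen-bond acceptor together, so the compounds shown do not tell which of the two goes with the step. An ethyl or a hydroxyl group at the same place on the core of compound 4 would begin to separate them.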